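This account rests on a few compounds, and the source may have more. Where it says the series, first, only, none or still open, it means among the compounds named here.

For the measured compounds named here, compound 3 `CCCCCCCCS(=O)(=O)Nc1ccc(-c2ccccc2F)cc1C(=O)O` gives 34600 nM in an assay on mitochondria (strain BALB/c) for inhibition of glycerol-3-phosphate acyltransferase 1, mitochondrial (Mus musculus), read by scintillation counting, with a stated time of 10 min (a higher number here means a weaker inhibitor, a lower number a stronger inhibitor), the highest of the three numbers measured so far. Compound 1 `CCCCCCCCS(=O)(=O)Nc1ccc(-c2ccc(CCCC)cc2)cc1C(=O)O` gives 9000 nM in this assay, and compound 2 `CCCCCCCCS(=O)(=O)Nc1ccc(-c2ccccc2OC)cc1C(=O)O` gives 27600 nM. The step from the butyl-bearing ring to the fluorine-bearing ring was a 3.8-fold higher number from compound 1 to compound 3 (0.58 log units; beyond the scatter), while swapping methoxy for fluoro on that ring gave a 1.3-fold higher number from compound 2 to compound 3 (0.10 log units; within the scatter), a difference that cannot be separated from noise.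

Compound 4 `CCCCCCCCS(=O)(=O)Nc1ccc(C(=O)c2ccccc2OC)cc1C(=O)O` has not been measured. The change is (2-methoxyphenyl)carbonyl in place of 2-fluorophenyl on an aromatic carbon. Going by the values given here, compound 2 shows that the 2-methoxyphenyl group itself sits within the scatter of compound 3, but no measured pair shows the effect of inserting a carbonyl between the rings. The step is therefore expected to be small, a 1.2-fold lower number from compound 3 to compound 4 (0.06 log units; within the scatter), with wide uncertainty. Compound 4 is estimated at 30000 nM, within a range from 10000 nM to 90000 nM.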

Compound 4, half-maximal inhibitory concentration: 59200 nM
For compound 4 the middle estimate is 2.0-fold (0.30 log units) below the measured one; the measured number falls inside the stated range.
By their numbers in this assay, from the lowest: compound 1; then compounds 2, 3 and 4 (each within the scatter of the next, the first and the last beyond it).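

Adding a carbonyl to the 2-methoxyphenyl group at this position makes a small but real difference in this assay (a 2.1-fold higher number from compound 2 to compound 4 (0.33 log units; beyond the scatter)). The same group in place of 2-fluorophenyl stays within the scatter (a 1.7-fold higher number from compound 3 to compound 4 (0.23 log units; within the scatter)), while in place of 4-butylphenyl it gives the largest step yet seen at this position (a 6.6-fold higher number from compound 1 to compound 4 (0.82 log units; beyond the scatter)). No measurement is available to explain these steps. The compounds shown leave open whether an amine in place of the carbonyl, or a longer chain on the outer ring, would bring the number closer to that of compound 1.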